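Series on the shared core: a second carboxy on the side chain

This account rests on a few compounds, and the source may have more. Where it says the series, first, only, none or still open, it means among the compounds named here.

Three compounds of the series have numbers in a functional assay on the whole organism (Tail, strain ICR) with Mus musculus as the target, in the tail flick test, with a stated time of 150 min, at a dose of 25 umol/kg by the oral route; on this read-out lower numbers stand for a weaker effect and higher numbers for a stronger effect at the one dose given. Compound 1 `O=C(O)[C@@H]1CCCN1C(=O)CN(c1nc(Cl)nc2[nH]cnc12)C1CC1` gives 7.29% in this assay. Compound 2 `N=C(N)NCCC[C@H](NC(=O)CN(c1nc(Cl)nc2[nH]cnc12)C1CC1)C(=O)OCc1ccccc1` gives 6.12% in this assay. Compound 3 `C[C@H](NC(=O)CN(c1nc(Cl)nc2[nH]cnc12)C1CC1)C(=O)O` gives 14.7% in this assay; its number lies nearest to that of compound 1 and furthest from that of compound 2, both gaps within the scatter, so no ranking among the three can be drawn.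

Within the data shown here, the only single-point step measured so far is a number 7.4 percentage points higher from compound 1 to compound 3 (within the scatter), which is within the scatter.

Compound 4 `O=C(O)C[C@H](NC(=O)CN(c1nc(Cl)nc2[nH]cnc12)C1CC1)C(=O)O` differs from compound 3 by carboxy in place of hydrogen on a saturated chain carbon, two bonds along the chain from an amide-type nitrogen and a carbonyl carbon. Among the measured compounds shown here, no measured step bears directly on adding a carboxy at this place; the one step known, from compound 1 to compound 3, reshaped the amide side without moving the number beyond the scatter, and every value so far sits within the scatter of the others. A change beyond the scatter in this assay is therefore not expected for compound 4, and the step is estimated as a number 4.7 percentage points lower from compound 3 to compound 4 (within the scatter).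

Compound 4 is expected to give about 10% in this assay, with a range from 2% to 20%.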

Compound 4, a percentage reported as activity, at one dose (the size of the read-out at that dose, not a potency): 11.6%
Compound 4: the middle estimate sits 1.6 percentage points below what was measured, and the stated range covers the measured number.
By their numbers in this assay, from the lowest: compounds 2, 1, 4 and 3 (each within the scatter of the next).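

Among these compounds, at this place, on a saturated chain carbon, two bonds along the chain from an amide-type nitrogen and a carbonyl carbon, the first direct reading for carboxy in place of hydrogen is a number 3.1 percentage points lower from compound 3 to compound 4 (within the scatter) in this assay as the read-out. The same change, read as methyl to carboxymethyl, therefore adds a second carboxy to the side chain without a step that stands clear of the scatter. No measurement offered here accounts for this step.

The compounds shown leave open whether a primary amine or a carboxamide on this carbon, or a longer chain carrying the carboxy, would give a step beyond the scatter. They also leave open whether any change on this side chain can be told apart from the others at this one dose and time.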